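Ring-opened sulfamoyl analogue of a piperidine ester

The source may report more compounds than this note shows. Statements on the series, on what has been measured and on what is new or still open speak of the compounds shown alone.

Measured so far:
- compound 1, `CCOC(=O)[C@@H]1CCCN(S(=O)(=O)c2ccc(S(=O)(=O)N3CCCCC3)cc2)C1`: 2900 nM in a functional assay on MIA PaCa-2 cells (Homo sapiens) for inhibition, read by MTT assay, with a stated time of 7 days; a lower number here means a stronger inhibitor, a higher number a weaker inhibitor
- compound 2, `CCOC(=O)C1CN(S(=O)(=O)c2ccc(S(=O)(=O)N(CC)CC)cc2)C1`: 13900 nM in this assay

Compound 1 has the lower of the two numbers in this assay; compound 2 sits at a higher number, and the gap between them lies beyond the scatter. The two compounds differ in more than one place, so their values show only that much and no single change can be read from them.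

Compound 3, `CCCN(CC)S(=O)(=O)c1ccc(S(=O)(=O)N2CCC[C@@H](C(=O)OCC)C2)cc1`, is not yet measured. It departs from compound 1 in one place only: ethyl(propyl)amino in place of piperidin-1-yl on a sulfonyl sulfur. The sulfonyl-bound amine goes from a ring to an open chain of the same heavy-atom count, while the ester-bearing ring of compound 1 is kept.

Within the data shown here, no measured pair isolates this change. Compound 2, the only other point, carries an open-chain amine on that sulfur and also a smaller ester-bearing ring, so it cannot settle the question. A step in this assay of modest size towards a higher number is expected, though one within the scatter is possible. The step expected is a 1.6-fold higher number from compound 1 to compound 3 (0.19 log units; within the scatter). For compound 3 the expected value in this assay is 4500 nM, with a range of 1800 nM to 12000 nM.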

Compound 3, half-maximal inhibitory concentration: 300 nM
Beside the measured number, compound 3's estimate is 15-fold (1.18 log units) above it; the measured number lies below the stated range.
By their numbers in this assay, from the lowest: compound 3; then compound 1; then compound 2.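

Notes on the sulfonyl-bound amine: in this assay, with the ester-bearing ring kept and the heavy-atom count unchanged, replacing piperidin-1-yl with ethyl(propyl)amino on a sulfonyl sulfur gives a 9.7-fold lower number from compound 1 to compound 3 (0.99 log units; beyond the scatter), a step beyond the usual scatter. This shows that the potency of the series responds to the form of this amine, even when a ring and an open chain are matched in their heavy atoms and in their carbon and nitrogen content, which compound 1 and compound 2 could not show, as they differ in more than one place. No measurement at hand speaks to what lies behind this step.

One step cannot say whether the lower number follows from open-chain amines in general or from this particular ethyl and propyl pairing, and a dipropylamino or dibutylamino group on the same sulfur would bear on that. On these data alone, it also remains open whether the step holds when the ethyl ester of compound 3 gives way to a carboxylic acid or an amide.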